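Methylsulfanyl for methoxy on the core of compound 1

The source may hold more compounds than are shown below. What is called first, only, known or untested is meant among the compounds shown, and "the series" means these compounds.

The series shares a nucleoside-like core carrying a five-membered aryl group, and is tested in a functional assay on HCT-116 cells (Homo sapiens), read by MTT assay, with a stated time of 72 h; on this read-out lower numbers stand for stronger inhibition and higher numbers for weaker inhibition. Compound 1 `COc1ncnc2c1c(-c1cccs1)cn2[C@@H]1O[C@H](CO)[C@@H](O)[C@H]1O` gives 80 nM in this assay, the lowest of the two numbers shown. Compound 2 `COc1ncnc2c1c(-c1ccccc1)cn2[C@@H]1O[C@H](CO)[C@@H](O)[C@H]1O` reaches only the limit > 20000 nM in this assay, which is a limit of the assay and not a number. Compound 3 `COc1ncnc2c1c(-c1cc3ccccc3o1)cn2[C@@H]1O[C@H](CO)[C@@H](O)[C@H]1O` gives 13800 nM in this assay. The measured steps concern the aryl group: an at least 250-fold higher number from compound 1 to compound 2 (2.39 log units; beyond the scatter) and a 170-fold higher number from compound 1 to compound 3 (2.24 log units; beyond the scatter), while an at least 1.4-fold lower number from compound 2 to compound 3 (0.16 log units; that floor lies within the scatter). Compound 4 `CSc1ncnc2c1c(-c1cccs1)cn2[C@@H]1O[C@H](CO)[C@@H](O)[C@H]1O` differs from compound 1 at another place: methylsulfanyl in place of methoxy on an aromatic carbon. Among the measured compounds shown here, no measured step touches this position, so the expectation rests on compound 1 alone, and no step beyond the scatter is expected in either direction. Compound 4 is therefore estimated at 100 nM in this assay, between 25 nM and 400 nM, which means an expected step of a 1.3-fold higher number from compound 1 to compound 4 (0.10 log units; within the scatter).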

Compound 4, half-maximal inhibitory concentration: > 20000 nM
Compound 4 was reported as a limit (the forecaster's own chance of this, stated with the estimate: 5%); middle value at least 200-fold (2.30 log units) from the limit.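

Among the compounds shown here, the position on the shared core that no earlier step touched is not indifferent: in this assay, methylsulfanyl in place of methoxy, with the thiophen-2-yl group kept, gives an at least 250-fold higher number from compound 1 to compound 4 (2.39 log units; beyond the scatter). The low number of compound 1 therefore depends on the methoxy group as well as on the thiophen-2-yl group, since a change at either place, among those shown, brings a large step to a higher number. Compound 4 is given only as a limit of the assay, > 20000 nM, not as a number, and it is not alone there: the limit of > 20000 nM in this assay, at which 2 of the 4 values shown sit.

The compounds shown leave open whether an amino group, a chlorine atom or a longer chain such as ethoxy at this place would keep the number of compound 1. They also leave open how far above the limit compound 4 really lies.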